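A cyclohexyl group on the sulfonyl sulfur

The source may hold more compounds than are shown below. What is called first, only, known or untested is meant among the compounds shown, and "the series" means these compounds.

In a physicochemical assay for solubility, with a stated time of 24 h (on this read-out higher numbers stand for higher solubility and lower numbers for lower solubility), compound 1 `COc1cccc(S(=O)(=O)c2ccc(CN/C(=N\C#N)Nc3ccncc3)cc2)c1` gives 51000 nM, compound 2 `N#C/N=C(\NCc1ccc(S(=O)(=O)c2cccc(C(F)(F)F)c2)cc1)Nc1ccncc1` gives 28000 nM and compound 3 `N#C/N=C(\NCc1ccc(S(=O)(=O)c2cccc(OC(F)(F)F)c2)cc1)Nc1ccncc1` gives 16000 nM. Compound 3 stands within the scatter of compound 2, as a 1.8-fold lower number from compound 2 to compound 3 (0.24 log units; within the scatter) shows, and clearly apart from compound 1.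

Compound 4 `N#C/N=C(\NCc1ccc(S(=O)(=O)C2CCCCC2)cc1)Nc1ccncc1`, not yet measured, differs from compound 3 by cyclohexyl in place of 3-(trifluoromethoxy)phenyl on a sulfonyl sulfur. In words, it has cyclohexyl in place of 3-(trifluoromethoxy)phenyl on a sulfonyl sulfur. The measured steps bear on this change only indirectly, as each swaps one group on an aromatic ring and none replaces the ring itself. Two are small, a 1.8-fold lower number from compound 1 to compound 2 (0.26 log units; within the scatter) and a 1.8-fold lower number from compound 2 to compound 3 (0.24 log units; within the scatter). The only one beyond the scatter is a 3.2-fold lower number from compound 1 to compound 3 (0.50 log units; beyond the scatter), and it leads to the trifluoromethoxy group that compound 4 no longer carries. Among the measured compounds shown here, no measured compound has a non-aromatic ring on the sulfonyl sulfur, so the direction is uncertain, but a modest rise in this assay is expected. The expected size is a 2.5-fold higher number from compound 3 to compound 4 (0.40 log units; beyond the scatter). For compound 4 the estimated value is 40000 nM, with an expected range of 14000 nM to 110000 nM.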

Compound 4, solubility: > 100000 nM
Compound 4 was reported as a limit; the forecaster's own chance of this, stated with the estimate: 5%; middle value at least 2.5-fold (0.39 log units) from the limit.
By their numbers in this assay, from the lowest: compounds 3, 2 and 1 (each within the scatter of the next, the first and the last beyond it). At a limit, above all of these: compound 4.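

In this assay compound 4 gives a limit and not a number: the limit of > 100000 nM in this assay, at which 1 of the 4 values shown sits.

Among the compounds shown here, compound 1, compound 2 and compound 3 differ only in a group on the aromatic ring, whereas compound 4 shows what happens when the ring on the sulfonyl sulfur is itself replaced, with cyclohexyl in place of the substituted aromatic ring, and even as floors the steps of an at least 6.2-fold higher number from compound 3 to compound 4 (0.79 log units; beyond the scatter) and an at least 3.5-fold higher number from compound 2 to compound 4 (0.55 log units; beyond the scatter) are larger than any of the earlier steps among the aromatic compounds. The remaining comparison reads an at least 1.9-fold higher number from compound 1 to compound 4 (0.29 log units; that floor lies within the scatter), so the limit does not settle how compound 4 stands relative to compound 1, which carries 3-methoxyphenyl on the same sulfur.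

As far as these compounds go, how far the true figure for compound 4 lies past the limit stays open, as does whether the difference goes with the non-aromatic ring or with the loss of the substituent, a question that a plain phenyl on the sulfonyl sulfur would address. Also open, from the compounds shown here alone, is what a straight butyl chain, or a cyclohexyl carrying an amine, would give at this position.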